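Dihydropyridine sulfonamide series: antiproliferative numbers and a new amide replacement

The source may report more compounds than this note shows. Statements on the series, on what has been measured and on what is new or still open speak of the compounds shown alone.

Measured compounds:
- compound 1, `CC(=O)NC1=C(C#N)C(c2ccc(Cl)cc2)C2=C(CC(C)(C)CC2=O)N1c1ccc(S(N)(=O)=O)cc1`: 64500 nM
- compound 2, `CCO/C=N/C1=C(C#N)C(c2ccc(Cl)cc2)C2=C(CC(C)(C)CC2=O)N1c1ccc(S(N)(=O)=O)cc1`: 97200 nM
- compound 3, `CCNC(=S)NC1=C(C#N)C(c2ccc(Cl)cc2)C2=C(CC(C)(C)CC2=O)N1c1ccc(S(N)(=O)=O)cc1`: 99600 nM

All three numbers come from a functional assay on MCF7 cells (Homo sapiens) for antiproliferative activity, read by sulforhodamine B assay, with a stated time of 48 h; on this read-out higher numbers stand for weaker inhibition and lower numbers for stronger inhibition. Compound 1 holds the lowest of the three, but its nearest neighbour is compound 2 at a 1.5-fold higher number from compound 1 to compound 2 (0.18 log units; within the scatter), and the furthest is compound 3 at a 1.5-fold higher number from compound 1 to compound 3 (0.19 log units; within the scatter), so none of the three is separated from another. Compound 2 and compound 3 sit essentially together, a 1.0-fold higher number from compound 2 to compound 3 (0.01 log units; within the scatter).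

The new compound is compound 4, `CC1(C)CC(=O)C2=C(C1)N(c1ccc(S(N)(=O)=O)cc1)C(N1C(=O)CCC1=O)=C(C#N)C2c1ccc(Cl)cc1`. Relative to compound 1 the change is 2,5-dioxopyrrolidin-1-yl in place of acetamido on a double-bonded ring carbon. For the measured compounds named here, the steps that bear on it are those from compound 1 to compound 2 and from compound 1 to compound 3, both of which alter what is attached at the same double-bonded ring carbon of the shared core and both of which stayed within the scatter. On this basis no step beyond the scatter is expected in this assay for compound 4, with a slight lean toward a higher number given that both measured neighbours of compound 1 lie above it.

Compound 4 is therefore expected at 85000 nM, within 30000 nM to 250000 nM, meaning an expected step of a 1.3-fold higher number from compound 1 to compound 4 (0.12 log units; within the scatter).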

Compound 4, half-maximal inhibitory concentration: 95200 nM
Estimate against measurement, compound 4: 1.1-fold (0.05 log units) below; measured number inside the range.
By their numbers in this assay, from the lowest: compounds 1, 4, 2 and 3 (each within the scatter of the next).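

For the compounds shown here, the double-bonded ring carbon tolerates a larger change than the earlier compounds showed: in this assay, 2,5-dioxopyrrolidin-1-yl brings a five-membered non-aromatic ring and 0 hydrogen-bond donors in place of acetamido with 1 hydrogen-bond donor, and this gives only a step within the scatter (a 1.5-fold higher number from compound 1 to compound 4 (0.17 log units; within the scatter)). Compound 4 also cannot be told apart from the two compounds with no ring in this substituent (a 1.0-fold lower number from compound 2 to compound 4 (0.01 log units; within the scatter); a 1.0-fold lower number from compound 3 to compound 4 (0.02 log units; within the scatter)), so across these four compounds neither the ring nor the loss of the amide hydrogen separates one number from another. No measurement here gives a reason for this flat reading.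

On these data alone, all four substituents leave the numbers within the scatter of one another, so it remains open whether this position can move the read-out at all. A free amine, a carboxylic acid or a longer alkyl chain on the same carbon would test this, as would an aromatic ring such as phenyl in place of the 2,5-dioxopyrrolidin-1-yl group.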